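This account rests on a few compounds, and the source may have more. Where it says the series, first, only, none or still open, it means among the compounds named here.

In an ADME assay on a cell-free system (plasma, Rattus norvegicus) for metabolic stability, read by LC-MS, with a stated time of 60 min, at 37 degrees C, tested at 50 uM (on this read-out higher numbers stand for a more stable compound and lower numbers for a less stable compound), compound 3 `CCOC(=O)OCOC(=O)C1=C(S[C@@H]2CN[C@H](C(=O)Nc3cccc(C(=O)O)c3)C2)[C@H](C)[C@@H]2[C@@H]([C@@H](C)O)C(=O)N12` gives 0%, level with compound 1 `CCC(CC)C(=O)OCOC(=O)C1=C(S[C@@H]2CN[C@H](C(=O)Nc3cccc(C(=O)O)c3)C2)[C@H](C)[C@@H]2[C@@H]([C@@H](C)O)C(=O)N12`, which gives 0%, and with compound 2 `C[C@@H](O)[C@H]1C(=O)N2C(C(=O)OCOC(=O)OC3CCCCC3)=C(S[C@@H]3CN[C@H](C(=O)Nc4cccc(C(=O)O)c4)C3)[C@H](C)[C@H]12`, which gives 0%. Compound 4 `COC(=O)OCOC(=O)C1=C(S[C@@H]2CN[C@H](C(=O)Nc3cccc(C(=O)O)c3)C2)[C@H](C)[C@@H]2[C@@H]([C@@H](C)O)C(=O)N12` differs from compound 3 only on a saturated chain carbon bound to an oxygen next to a carbonyl group: hydrogen in place of methyl on a saturated chain carbon bound to an oxygen next to a carbonyl group. The measured steps that bear on this change alter the same end of the molecule. no change at the digits printed from compound 1 to compound 3 (within the scatter), and no change at the digits printed from compound 2 to compound 3 (within the scatter); likewise no change at the digits printed from compound 1 to compound 2 (within the scatter). Those exchanges left the read-out where it was, so for compound 4 no step beyond the scatter is expected in this assay, namely no change at the digits printed from compound 3 to compound 4 (within the scatter). Compound 4 is therefore estimated at 0%, within 0% to 8%.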

Compound 4, percent of the compound remaining: 0%
For compound 4 middle estimate and measured number coincide at the digits printed; low and high end bracket the measured number.
By their numbers in this assay, from the lowest: compounds 1, 2, 3 and 4 (each within the scatter of the next).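

In this assay, replacing ethoxycarbonyl with methoxycarbonyl adds one more exchange at this end of the molecule that leaves the result unmoved: no change at the digits printed from compound 3 to compound 4 (within the scatter). The comparisons with the cyclohexyl and pentan-3-yl compounds read the same, with no change at the digits printed from compound 2 to compound 4 (within the scatter) and no change at the digits printed from compound 1 to compound 4 (within the scatter). Nothing given here explains this result.

All four compounds sit at the same bottom reading, so any differences in how quickly they disappear within the stated time stay hidden. As far as these compounds go, whether an amine or a carboxylic acid at this place would leave any compound remaining stays open.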